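A few compounds are considered here, and "the series" means these few. Any claim that something is new, unique, unknown or untested is made for them only; others in the source may bear on it.

Working notes on the series. The three measured compounds share the core of compound 1 `CCCC(=O)Nc1ccc(S(=O)(=O)Oc2ccccc2C(C)C)cc1` and differ only in the chain attached to the carbonyl carbon. In a functional assay on MCF7 cells (Homo sapiens) for antiproliferative activity, read by sulforhodamine B assay, with a stated time of 48 h (on this read-out lower numbers stand for stronger inhibition and higher numbers for weaker inhibition), compound 1 gives 6600 nM. Compound 2 `CCCCCC(=O)Nc1ccc(S(=O)(=O)Oc2ccccc2C(C)C)cc1` gives 5300 nM in this assay. Compound 3 `CC(C)c1ccccc1OS(=O)(=O)c1ccc(NC(=O)CCCCl)cc1` gives 5200 nM in this assay. The steps of a 1.2-fold lower number from compound 1 to compound 2 (0.10 log units; within the scatter) and a 1.3-fold lower number from compound 1 to compound 3 (0.10 log units; within the scatter) are within the scatter, as is a 1.0-fold lower number from compound 2 to compound 3 (0.01 log units; within the scatter); on these numbers compound 3 cannot be set apart from compound 1 or compound 2.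

Compound 4 `CCNC(=O)Nc1ccc(S(=O)(=O)Oc2ccccc2C(C)C)cc1` carries a change of a different kind: ethylamino in place of 3-chloropropyl on a carbonyl carbon, so that ethylcarbamoyl stands in place of (3-chloropropyl)carbonyl. Within the data shown here, no measured step touches the carbonyl carbon's substituent in this way; the measured steps vary only the tail of the chain, and all lie within the scatter. Nothing measured bears directly on this step, so the expectation for compound 4 is a number near that of compound 3 with a wide range. Compound 4 is estimated at 5500 nM, between 2000 nM and 15000 nM. The expected step is a 1.1-fold higher number from compound 3 to compound 4 (0.02 log units; within the scatter), not beyond the scatter.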

Compound 4, half-maximal inhibitory concentration: 10000 nM
Compound 4: middle estimate off by 1.8-fold (0.26 log units), on the low side; the range from low to high includes it.
By their numbers in this assay, from the lowest: compounds 3, 2, 1 and 4 (each within the scatter of the next).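

In this assay the three steps to ethylamino on the carbonyl carbon, a 1.9-fold higher number from compound 3 to compound 4 (0.28 log units; within the scatter) and a 1.9-fold higher number from compound 2 to compound 4 (0.28 log units; within the scatter) and a 1.5-fold higher number from compound 1 to compound 4 (0.18 log units; within the scatter) all stay within the scatter, so compound 4 cannot be set apart from the other three compounds. The earlier compounds shown here varied only the tail of the chain, whereas this change alters the atom bonded to the carbonyl carbon and brings in one hydrogen-bond donor, and still no step beyond the scatter appears at this position. No measurement at hand explains the values of compound 4.

Open, going by these compounds, is whether a longer alkylamino chain or a phenylamino group on the carbonyl carbon would move the number beyond the scatter. Also open, on these data alone, is whether a carboxylic acid or an amine at the end of the chain would do so.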